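Oral exposure notes: from compound 2 to compound 3

The compounds below may be only part of what the source reports. "The series", "measured", "known", "first", "only" and "open" are said of these compounds alone.

Compound 1 `CC/C(=C(/c1ccc(/C=C/C(=O)O)cc1)c1ccc2[nH]ccc2c1)c1ccccc1`: 9400 ng.h/mL
Compound 2 `CC/C(=C(/c1ccc(/C=C/C(=O)O)cc1)c1ccc2[nH]ncc2c1)c1ccccc1`: 5800 ng.h/mL

Both values come from an ADME assay on the whole organism for pharmacokinetics, with Mus musculus as the target, at a dose of 10 mg/kg by the oral route; a lower number here means less compound in the circulation, a higher number more compound in the circulation at the dose given. The two measured compounds lie within the scatter of each other, so compound 2 cannot be ranked against compound 1: a 1.6-fold lower number from compound 1 to compound 2 (0.21 log units; within the scatter).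

Next in line is compound 3 `CC/C(=C(/c1ccc(/C=C/C(=O)O)cc1)c1ccc2[nH]ncc2c1)c1ccc(C#N)cc1C`, still unmeasured. It carries 4-cyano-2-methylphenyl in place of phenyl on a double-bonded chain carbon bound to a double-bonded chain carbon and a saturated chain carbon.

Among the compounds with values here, only one measured step is available, and it bears on this change only indirectly. That step, a 1.6-fold lower number from compound 1 to compound 2 (0.21 log units; within the scatter), exchanges 1H-indol-5-yl for 1H-indazol-5-yl at a different place and stays within the scatter. Within the data shown here, no measured compound varies the phenyl, so the data give no direction for the new group. The expectation in this assay is therefore no step beyond the scatter, starting from compound 2 at 5800 ng.h/mL, and the range is kept wide.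

The expected step is a 1.6-fold higher number from compound 2 to compound 3 (0.19 log units; within the scatter).

For compound 3 the estimated value is 9000 ng.h/mL, with an expected range of 2500 ng.h/mL to 30000 ng.h/mL.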

Compound 3, area under the concentration-time curve: 4300 ng.h/mL
Compound 3: middle estimate off by 2.1-fold (0.32 log units), on the high side, within the range that was stated.
By their numbers in this assay, from the lowest: compounds 3, 2 and 1 (each within the scatter of the next, the first and the last beyond it).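

Working notes, position on the double-bonded chain carbon bound to a double-bonded chain carbon and a saturated chain carbon: compound 3 gives the first measured change to the phenyl at this position, and in this assay the exchange for 4-cyano-2-methylphenyl reads as a 1.3-fold lower number from compound 2 to compound 3 (0.13 log units; within the scatter), so compound 3 cannot be separated from compound 2. At this position and in this assay, a nitrile and a methyl carried together on the phenyl therefore produce no step beyond the scatter, on the core of compound 2 with its 1H-indazol-5-yl group. No measurement bears on why this is so.

The nitrile and the methyl enter together, so the contribution of each to this assay remains unresolved, and a phenyl carrying only one of them would be needed to separate them. Also open, as far as these compounds go, is whether the same reading holds for other groups on this ring, such as an amine or a carboxylic acid in place of the nitrile, or a longer chain in place of the methyl.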